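The source may hold more compounds than are shown below. What is called first, only, known or untested is meant among the compounds shown, and "the series" means these compounds.

Compound 2 `Cc1cc(C)c(Oc2cc(Nc3ccc(C#N)cc3)[nH]c(=O)c2I)c(C)c1` sits in a short series of pyridinone anilines beside compound 1 `Cc1cccc(C)c1Oc1cc(Nc2ccc(C#N)cc2)[nH]c(=O)c1Cl` and compound 3 `Cc1cc(C)cc(Oc2cc(Nc3ccc(C#N)cc3)[nH]c(=O)c2I)c1`. In an ADME assay on MT4 cells (Homo sapiens) for cytotoxicity, read by MTT assay, with a stated time of 5 days (a higher number here means that more compound is tolerated, a lower number that less compound is tolerated), compound 2 gives 34000 nM, compound 1 gives 29000 nM and compound 3 gives 24000 nM; compound 2 carries the largest of the three numbers, but its gaps to compound 1 and compound 3 both lie within the scatter. Compound 4 `Cc1cc(C)c(Oc2cc(Nc3ccc(C#N)cc3)[nH]c(=O)c2Br)c(C)c1` differs from compound 2 by bromo in place of iodo on an aromatic carbon. Within the data shown here, no measured step swaps one halogen for another; the only step on record, a 1.4-fold lower number from compound 2 to compound 3 (0.15 log units; within the scatter), concerns the aryl ether and is within the scatter. Compound 4 is therefore expected to show no step beyond the scatter, no change at the digits printed from compound 2 to compound 4 (within the scatter), with an estimated 34000 nM in a range of 17000 nM to 68000 nM.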

Compound 4, half-maximal cytotoxic concentration: > 294000 nM
Compound 4: a limit, no number; the forecaster's own chance of this, stated with the estimate: 10%; at least 8.6-fold (0.93 log units) between middle value and limit.
By their numbers in this assay, from the lowest: compounds 3, 1 and 2 (each within the scatter of the next). At a limit, above all of these: compound 4.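

At this position, on an aromatic carbon two atoms from the ring nitrogen, bromo in place of iodo gives the only step beyond the scatter shown in this assay: an at least 8.6-fold higher number from compound 2 to compound 4 (0.93 log units; beyond the scatter). The earlier step, a 1.4-fold lower number from compound 2 to compound 3 (0.15 log units; within the scatter), concerns the aryl ether and lies within the scatter. Compound 4 gives a limit and no number: the limit of > 294000 nM in this assay, at which 1 of the 4 values shown sits.

As far as these compounds go, how far compound 4 lies past that limit stays open. Also open, from the compounds shown here alone, is what an amino or a methoxy group on this aromatic carbon would give with the same 2,4,6-trimethylphenyl ether.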